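Aryl Triazole Esters: Halogenated Phenyl Variants and Antiproliferative Potency

The source may hold more compounds than are shown below. What is called first, only, known or untested is meant among the compounds shown, and "the series" means these compounds.

Compound 1, `C/C(=C\CC/C(C)=C/CC[C@@H]1[C@@]2(C)CCC(=O)C(C)(C)[C@H]2CC[C@@]1(C)O)CC/C=C(\C)C(=O)OCc1cn(-c2cccc(O)c2)nn1`: 28400 nM
Compound 2, `C/C(=C\CC/C(C)=C/CC[C@@H]1[C@@]2(C)CCC(=O)C(C)(C)[C@H]2CC[C@@]1(C)O)CC/C=C(\C)C(=O)OCc1cn(-c2ccc(F)c(Cl)c2)nn1`: > 150000 nM
Compound 3, `C/C(=C\CC/C(C)=C/CC[C@@H]1[C@@]2(C)CCC(=O)C(C)(C)[C@H]2CC[C@@]1(C)O)CC/C=C(\C)C(=O)OCc1cn(-c2cccc(C(F)(F)F)c2)nn1`: > 150000 nM

These three compounds share a core and differ only in the phenyl group carried on an aromatic nitrogen of the triazole ring. In a functional assay on DU-145 cells (Homo sapiens) for antiproliferative activity, read by MTT assay, with a stated time of 48 h (on this read-out higher numbers stand for weaker inhibition and lower numbers for stronger inhibition), compound 1 gives 28400 nM. For compound 2 the value > 150000 nM is a limit of the assay rather than a number. For compound 3 the value > 150000 nM is likewise only a limit, so compound 3 stands at the weak end of the set, together with compound 2 (the limit of > 150000 nM in this assay, at which 2 of the 3 values shown sit).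

The step to compound 4, `C/C(=C\CC/C(C)=C/CC[C@@H]1[C@@]2(C)CCC(=O)C(C)(C)[C@H]2CC[C@@]1(C)O)CC/C=C(\C)C(=O)OCc1cn(-c2ccc(Cl)cc2)nn1`, is 4-chlorophenyl in place of 3-(trifluoromethyl)phenyl on an aromatic nitrogen. Among the compounds with values here, the steps that bear on it are an at least 5.2-fold higher number from compound 1 to compound 3 (0.72 log units; beyond the scatter) and a step that the two limits leave unreadable from compound 2 to compound 3. Compound 2, which also carries a halogenated phenyl, sits at the same limit as compound 3, so no gain is expected from exchanging one halogenated phenyl for another. The expected step is a number no higher from compound 3 to compound 4 (the limit leaves the size open), no change beyond the scatter, with a high chance that only a limit is reported again. Compound 4 is therefore estimated at 150000 nM, between 40000 nM and 400000 nM.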

Compound 4, half-maximal inhibitory concentration: > 150000 nM
Compound 4 gave a limit, no number (the forecaster's own chance of this, stated with the estimate: 65%); the middle value sits exactly at the limit.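

In this assay, within the data shown here, compound 4 also returns only a limit, so 4-chlorophenyl joins 3-chloro-4-fluorophenyl and 3-(trifluoromethyl)phenyl at the weak end of the set: the limit of > 150000 nM in this assay, at which 3 of the 4 values shown sit. The one readable new step is an at least 5.2-fold higher number from compound 1 to compound 4 (0.72 log units; beyond the scatter), which shows that the loss on leaving 3-hydroxyphenyl also holds for a phenyl group carrying a single chlorine, not only for the two groups with fluorine. The steps among compound 2, compound 3 and compound 4 cannot be read, as limits stand at both ends, so the set gives no order among these three halogen-bearing groups.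

Compound 1 remains the only compound here with a number, at 28400 nM, so the compounds shown leave open whether the hydroxy group itself carries the activity or whether other groups on the phenyl ring would serve as well. An amine, a carboxylic acid or a methoxy group in its place, or a hydroxy group in the place the chlorine holds in 4-chlorophenyl, could show whether a number lower than that of compound 1 is within reach at this position.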